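Pyridine in Place of Pyrimidine on a Thiophene Core

The source may report more compounds than this note shows. Statements on the series, on what has been measured and on what is new or still open speak of the compounds shown alone.

Three compounds share one core and differ only in the aromatic group attached to the fused two-ring system. Compound 1 `CC#C[C@@H](Cc1nnn[nH]1)c1ccc(OCc2ccc3scc(-c4cncnc4C)c3c2)cc1` was tested in an ADME assay on microsomes from liver (Rattus norvegicus) for metabolic stability (a lower number here means that the compound disappears faster, a higher number that the compound lasts longer), where compound 1 gives 0.333 h. That is the lowest of the two numbers measured. Compound 3 `CC#C[C@@H](Cc1nnn[nH]1)c1ccc(OCc2ccc3scc(-c4ccc(OCCC(C)(C)O)cc4C)c3c2)cc1` in this assay gives 1.03 h, a value beyond the usual scatter of the method when set against compound 1. Compound 2 `CC#C[C@@H](Cc1nnn[nH]1)c1ccc(OCc2ccc3sc(C(F)(F)F)c(-c4ccc(OCCOC)cc4C)c3c2)cc1` reaches only a limit of the assay: in this assay compound 2 gives > 3 h, which is a limit and not a number (the limit of > 3 h in this assay, at which 1 of the 3 values shown sits).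

Compound 4 `CC#C[C@@H](Cc1nnn[nH]1)c1ccc(OCc2ccc3scc(-c4cccnc4C)c3c2)cc1` has not yet been measured. It differs from compound 1 in one place (2-methylpyridin-3-yl in place of 4-methylpyrimidin-5-yl on an aromatic carbon). For this exchange of one small six-membered heteroaromatic group for another, a step in this assay no larger than the usual scatter is expected, in either direction. The step from compound 1 to compound 4 is estimated at a 1.0-fold lower number from compound 1 to compound 4 (0.00 log units; within the scatter). Compound 4 is therefore expected to give 0.33 h in this assay, most likely between 0.13 h and 0.8 h.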

Compound 4, half-life: 0.183 h
For compound 4 the middle estimate is 1.8-fold (0.26 log units) above the measured one, and the stated range covers the measured number.
By their numbers in this assay, from the lowest: compounds 4 and 1 (each within the scatter of the next); then compound 3. At a limit, above all of these: compound 2.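

Within this assay, replacing 4-methylpyrimidin-5-yl with 2-methylpyridin-3-yl gives a 1.8-fold lower number from compound 1 to compound 4 (0.26 log units; within the scatter). This is the first step shown between two compounds that differ in one place, on an aromatic carbon of the five-membered aromatic ring, two ring bonds from the ring sulfur: with the ring size and heavy-atom count unchanged, going from two ring nitrogens to one moves the half-life by no more than the scatter. Nothing measured here on the properties of these two groups bears on this result.

The compounds shown leave open whether an amine or a carboxylic acid on the 2-methylpyridin-3-yl ring would move the half-life beyond the scatter. They also leave open whether the same exchange gives a similar step on a core carrying trifluoromethyl, as compound 2 does.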